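Fluoro for trifluoromethyl: compound 2 to compound 4

A few compounds are considered here, and "the series" means these few. Any claim that something is new, unique, unknown or untested is made for them only; others in the source may bear on it.

Of the compounds shown here, three on the shared core have been measured: compound 1 `Nc1scc(CN2CCN(c3ccc([N+](=O)[O-])cc3)CC2)c1C(=O)c1ccc(Cl)cc1`, compound 2 `Nc1scc(CN2CCN(c3cccc(C(F)(F)F)c3)CC2)c1C(=O)c1ccc(Cl)cc1` and compound 3 `Nc1scc(CN2CCN(c3ccc(C(F)(F)F)cc3)CC2)c1C(=O)c1cccc(C(F)(F)F)c1`. In a functional assay on CHO cells with adenosine receptor A1 (Homo sapiens) as the target, read by cAMP accumulation and immunoassay, with a stated time of 6 min, tested at 1 uM (on this read-out higher numbers stand for a weaker effect at the one concentration tested and lower numbers for a stronger effect), compound 1 gives -8.3%, compound 2 gives -72% and compound 3 gives -27%. Compound 2 stands lowest of the three, beyond the scatter from both others. Within the data shown here, the only single-place step measured is a number 63.7 percentage points lower from compound 1 to compound 2 (beyond the scatter), 3-(trifluoromethyl)phenyl in place of 4-nitrophenyl on an amine nitrogen in a ring. Compound 3 differs from compound 2 in two places, so its higher number cannot be assigned to either change.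

Compound 4 `Nc1scc(CN2CCN(c3cccc(F)c3)CC2)c1C(=O)c1ccc(Cl)cc1` is not yet measured. It differs from compound 2 by fluoro in place of trifluoromethyl on an aromatic carbon. Among the measured compounds shown here, no measured step exchanges fluoro for trifluoromethyl; the step from compound 1 to compound 2 shows only that the group on this ring can shift the number by a large amount. A moderate rise toward the other two compounds is therefore expected, a number 22 percentage points higher from compound 2 to compound 4 (beyond the scatter), with wide uncertainty. Compound 4 is estimated at -50%, range -80% to -10%.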

Compound 4, a percentage reported as activity, at one concentration (the size of the read-out at that concentration, not a potency): -86%
Estimate against measurement, compound 4: 36 percentage points above, and the stated range ends above it.
By their numbers in this assay, from the lowest: compound 4; then compound 2; then compound 3; then compound 1.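

In this assay, the step of a number 14 percentage points lower from compound 2 to compound 4 (beyond the scatter) shows that trifluoromethyl is not required at this place on the ring: fluoro, with 1 heavy atom against 4, gives a lower number, not a higher one. The step of a number 77.7 percentage points lower from compound 1 to compound 4 (beyond the scatter) places 3-fluorophenyl, like 3-(trifluoromethyl)phenyl, well below 4-nitrophenyl, although this step changes both the group and where it sits on the ring, so the two changes cannot be separated. No measurement available here bears on why the smaller group goes with the lower number.

As far as these compounds go, it remains open whether the number would hold or fall further with a hydrogen, a chlorine atom or a methoxy group at this place. Also open, from the compounds shown here alone, is whether fluoro keeps this result with a different group on the ketone.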